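The source may hold more compounds than are shown below. What is called first, only, known or untested is meant among the compounds shown, and "the series" means these compounds.

Measured compounds, all in a functional assay on HT cells (Homo sapiens) for antiproliferative activity, read by fluorescence, with a stated time of 72 h; on this read-out higher numbers stand for weaker inhibition of growth and lower numbers for stronger inhibition of growth:

- compound 1 `CC(C)c1n[nH]c2c(NCc3ccc(-c4ccccn4)cc3)nc(SCCC(N)=O)nc12` gives 120 nM
- compound 2 `CC(C)c1n[nH]c2c(NCc3ccc(-c4ccccn4)cc3)nc(SC(C)C(C)O)nc12` gives 190 nM
- compound 3 `C=CCSc1nc(NCc2ccc(-c3ccccn3)cc2)c2[nH]nc(C(C)C)c2n1` gives 1010 nM

Compound 3 carries the highest number of the three. Its nearest neighbour is compound 2, reached by a 5.3-fold higher number from compound 2 to compound 3 (0.73 log units; beyond the scatter), and the wider gap is an 8.4-fold higher number from compound 1 to compound 3 (0.93 log units; beyond the scatter); both steps lie beyond the scatter. Compound 1 and compound 2 differ from each other only by a 1.6-fold higher number from compound 1 to compound 2 (0.20 log units; within the scatter), which stays within the scatter.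

Compound 4 `CC(C)c1n[nH]c2c(NCc3ccc(-c4ccccn4)cc3)nc(S)nc12` has not yet been measured. The change from compound 3 is hydrogen in place of allyl on a sulfur. Going by the values given here, the steps so far that touch the sulfur all swap one chain for another there: an 8.4-fold higher number from compound 1 to compound 3 (0.93 log units; beyond the scatter) and a 5.3-fold higher number from compound 2 to compound 3 (0.73 log units; beyond the scatter) both move towards the allyl and both raise the number by a modest amount. Among the compounds with values here, no measured step removes the chain altogether and leaves a sulfanyl, so these steps bear on the change only loosely. With allyl already the weakest end of the measured set, and nothing to show that a bare sulfanyl restores the lower numbers of compound 1 or compound 2, the expected step is a 1.5-fold higher number from compound 3 to compound 4 (0.17 log units; within the scatter), a shift that would not exceed the scatter. Compound 4 is therefore estimated at 1500 nM, with a range from 400 nM to 6000 nM.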

Compound 4, concentration for 50% growth inhibition: 2760 nM
Beside the measured number, compound 4's estimate is 1.8-fold (0.26 log units) below it, and the stated range covers the measured number.
By their numbers in this assay, from the lowest: compounds 1 and 2 (each within the scatter of the next); then compound 3; then compound 4.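

In this assay, going by these compounds alone, the sulfur at this position was so far seen only with a chain on it, and the bare sulfanyl now gives the highest number of the series, even against allyl (a 2.7-fold higher number from compound 3 to compound 4 (0.44 log units; beyond the scatter)). Against the two substituted chains the gap is large, both for 2-hydroxy-1-methylpropyl (a 15-fold higher number from compound 2 to compound 4 (1.16 log units; beyond the scatter)) and for 2-carbamoylethyl (a 23-fold higher number from compound 1 to compound 4 (1.36 log units; beyond the scatter)). Across these four compounds, each of the three chains on the sulfur goes with a lower number than hydrogen there, and no compound shown goes against this, so allyl no longer marks the weak end of the set.

The compounds shown leave open whether a chain ending in an amine or a carboxylic acid, or a longer chain bearing the same amide or hydroxyl, would bring the number below those of compound 1 and compound 2, and whether an oxygen in place of the sulfur would keep them. Nothing available here gives a measured reason for the rise in number on losing the chain.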